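The compounds below may be only part of what the source reports. "The series", "measured", "known", "first", "only" and "open" are said of these compounds alone.

Measured so far:
compound 1, `C=CCn1c(=O)/c(=C\c2ccccc2Cl)[nH]c(=O)/c1=C\c1ccccc1OC`, giving 4700 nM
compound 2, `C=CCn1c(=O)/c(=C\c2cccc(Cl)c2Cl)[nH]c(=O)/c1=C\c1ccccc1OC`, giving 2100 nM
compound 3, `COc1ccccc1/C=c1\c(=O)[nH]/c(=C/c2cccc(Cl)c2Cl)c(=O)n1C`, giving 200 nM

All three were tested in a functional assay on MCF7 cells (Homo sapiens) for cytotoxicity, read by CCK-8 assay, with a stated time of 72 h; on this read-out lower numbers stand for stronger inhibition and higher numbers for weaker inhibition. Compound 2 and compound 1 differ by hydrogen in place of chloro on an aromatic carbon, and this gave a 2.2-fold higher number from compound 2 to compound 1 (0.35 log units; beyond the scatter). Compound 2 and compound 3 differ in their cores by hydrogen in place of vinyl on a saturated chain carbon bound to an aromatic nitrogen, and this gave an 11-fold lower number from compound 2 to compound 3 (1.02 log units; beyond the scatter). Compound 4, `COc1ccccc1/C=c1\c(=O)[nH]/c(=C/c2ccccc2Cl)c(=O)n1C`, has not yet been measured. It differs from compound 3 by hydrogen in place of chloro on an aromatic carbon, the same change as the one between compound 2 and compound 1, which occurs twice among these compounds. For compound 4 a step of about the same size as the earlier one is expected, a 2.3-fold higher number from compound 3 to compound 4 (0.35 log units; beyond the scatter), because in this assay compound 3 gives 200 nM and the earlier step was a 2.2-fold higher number from compound 2 to compound 1 (0.35 log units; beyond the scatter). Accordingly compound 4 is estimated at 450 nM, with a likely range from 200 nM to 1000 nM.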

Compound 4, half-maximal inhibitory concentration: 200 nM
Beside the measured number, compound 4's estimate is 2.3-fold (0.35 log units) above it; measured number inside the range.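

In this assay, the change from 2,3-dichlorophenyl to 2-chlorophenyl gave no change at the digits printed from compound 3 to compound 4 (within the scatter), and the two cores do not separate on this change: the same change on two cores in this assay, a 2.2-fold higher number (0.35 log units; beyond the scatter) from compound 2 to compound 1 and no change at the digits printed (within the scatter) from compound 3 to compound 4, 2.2-fold (0.35 log units) apart, within the scatter of two such steps. Hydrogen in place of vinyl on the saturated chain carbon bound to the aromatic nitrogen gave a 24-fold lower number from compound 1 to compound 4 (1.37 log units; beyond the scatter), and this step likewise holds across the two chloro patterns: the same change on two cores in this assay, an 11-fold lower number (1.02 log units; beyond the scatter) from compound 2 to compound 3 and a 24-fold lower number (1.37 log units; beyond the scatter) from compound 1 to compound 4, 2.2-fold (0.35 log units) apart, within the scatter of two such steps. Each change therefore carried over within the scatter among these four compounds, but two cores do not show that it would carry to any other core, and the data give no cause for either step.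

The compounds shown leave open how a fluoro or methoxy group would compare with the chloro group on the aromatic ring. They also leave open how a longer chain or a carboxylic acid would compare on the aromatic nitrogen.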